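The compounds below may be only part of what the source reports. "The series", "measured", "known", "first", "only" and "open" are said of these compounds alone.

Within the data shown here, compound 1 `CCN(Cc1cccs1)C(=O)COc1ccc(C)cc1` stands lowest among the three measured members in an assay on HEK293 cells for agonist activity at transient receptor potential cation channel subfamily M member 8 (Homo sapiens), read by fluorescence and calcium flux, with a stated time of 15 min (on this read-out lower numbers stand for an effect already at smaller amounts and higher numbers for an effect only at larger amounts of compound), where compound 1 gives 8 nM. Compound 2 `CCN(Cc1cccnc1)C(=O)COc1ccc(C)cc1` gives 15400 nM and compound 3 `CCN(Cc1cc[nH]c1)C(=O)COc1ccc(C)cc1` gives 21800 nM, both far from compound 1: the steps are a 1900-fold higher number from compound 1 to compound 2 (3.28 log units; beyond the scatter) and a 2700-fold higher number from compound 1 to compound 3 (3.44 log units; beyond the scatter), while between the two weaker members the step is a 1.4-fold higher number from compound 2 to compound 3 (0.15 log units; within the scatter). Compound 4 `CCC(C)N(Cc1cccs1)C(=O)COc1ccc(C)cc1` keeps the thiophen-2-yl of compound 1 and differs only by ethyl in place of hydrogen on a saturated chain carbon bound to an amide-type nitrogen and a saturated chain carbon. Among the measured compounds shown here, none of the measured steps touches this position; all three replace the heteroaryl group, so they give no guide to the size of an alkyl extension here. For the measured compounds named here, with no bearing precedent, compound 4 is expected to stay close to compound 1, the step of a 1.9-fold higher number from compound 1 to compound 4 (0.27 log units; within the scatter) estimated within or only slightly beyond the scatter. Compound 4 is therefore estimated at 15 nM, in the range 3 nM to 80 nM.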

Compound 4, half-maximal effective concentration: 2000 nM
Beside the measured number, compound 4's estimate is 130-fold (2.12 log units) below it; measured number above the stated range.
By their numbers in this assay, from the lowest: compound 1; then compound 4; then compounds 2 and 3 (each within the scatter of the next).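

In this assay, ethyl in place of hydrogen on a saturated chain carbon bound to an amide-type nitrogen and a saturated chain carbon gives a 250-fold higher number from compound 1 to compound 4 (2.40 log units; beyond the scatter), a large step. This place on the core of compound 1 is therefore sensitive to substitution, and keeping the thiophen-2-yl does not by itself preserve the low number. No evidence on the origin of this step is available.

Open, on these data alone, is whether methyl at this place stays closer to compound 1 than ethyl does. Also open, as far as these compounds go, is how a longer chain or an amine-bearing chain would read there.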